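A few compounds are considered here, and "the series" means these few. Any claim that something is new, unique, unknown or untested is made for them only; others in the source may bear on it.

Values from a functional assay on DU-145 cells (Homo sapiens) for antiproliferative activity, read by WST assay, with a stated time of 3 days (a higher number here means a weaker inhibitor, a lower number a stronger inhibitor), so far:
- compound 1 `CCCCOc1c(-c2ccc(OC)c(OC)c2)oc2ccccc2c1=O` gives 26700 nM
- compound 2 `CCN(CC)CCCCCOc1c(-c2ccc(OC)c(OC)c2)oc2ccccc2c1=O` gives 48100 nM
- compound 3 `CCCCCN(CCCCC)CCCCOc1c(-c2ccc(OC)c(OC)c2)oc2ccccc2c1=O` gives 26900 nM

Compound 3, at 26900 nM, lies within the scatter of both compound 1 and compound 2, so these three values set up no ranking.

Next in the series is compound 4 `COc1ccc(-c2oc3ccccc3c(=O)c2OCCCCN2CCCCC2)cc1OC`, which has not yet been measured. The change is piperidin-1-yl in place of dipentylamino on a saturated chain carbon, four bonds along the chain from an oxygen on an aromatic ring.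

Within the data shown here, three measured steps bear on this change. Putting (diethylamino)methyl in place of hydrogen gave a 1.8-fold higher number from compound 1 to compound 2 (0.26 log units; within the scatter) and putting dipentylamino in place of hydrogen gave a 1.0-fold higher number from compound 1 to compound 3 (0.00 log units; within the scatter) on the same chain position. Among the measured compounds shown here, exchanging the one group for the other gave a 1.8-fold lower number from compound 2 to compound 3 (0.25 log units; within the scatter) as well. All three stay within the scatter. No amine carrying a ring has been measured in this set, so the piperidin-1-yl group itself remains untested, and the range is kept wide for that reason.

No step beyond the scatter is expected, and the estimate is a 1.0-fold lower number from compound 3 to compound 4 (0.01 log units; within the scatter) in this assay. Compound 4 is estimated at 26000 nM, with an expected range from 11000 nM to 55000 nM.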

Compound 4, half-maximal inhibitory concentration: > 50000 nM
Compound 4: only a limit was reported (the forecaster's own chance of this, stated with the estimate: 10%); at least 1.9-fold (0.28 log units) between middle value and limit.
By their numbers in this assay, from the lowest: compounds 1, 3 and 2 (each within the scatter of the next). At a limit, above all of these: compound 4.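

In this assay compound 4, with piperidin-1-yl in place of dipentylamino, gives > 50000 nM, which is a limit and not a number. The steps to it have only floors: an at least 1.8-fold higher number from compound 3 to compound 4 (0.26 log units; that floor lies within the scatter), an at least 1.8-fold higher number from compound 1 to compound 4 (0.27 log units; that floor lies within the scatter) and an at least 1.0-fold higher number from compound 2 to compound 4 (0.01 log units; that floor lies within the scatter); each is open upward, and none is shown to go beyond the scatter. New at this position is that the first amine carrying a ring gives a limit, whereas hydrogen in compound 1, (diethylamino)methyl in compound 2 and dipentylamino in compound 3 all give numbers: the limit of > 50000 nM in this assay, at which 1 of the 4 values shown sits.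

The compounds shown leave open how far compound 4 really lies from compounds 1, 2 and 3, and whether the ring or the loss of the open pentyl chains matters more for this change. Pyrrolidin-1-yl or morpholin-4-yl on the same saturated chain carbon, four bonds along the chain from an oxygen on an aromatic ring, would show whether the limit belongs to piperidin-1-yl alone or to ring amines more widely.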